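The source may hold more compounds than are shown below. What is called first, only, known or untested is meant among the compounds shown, and "the series" means these compounds.

Series notes, growth inhibition of MV4-11 cells. In a functional assay on MV4-11 cells (Homo sapiens) for inhibition, read by resazurin assay, with a stated time of 72 h (a higher number here means a weaker inhibitor of growth, a lower number a stronger inhibitor of growth), compound 1 `O=C1NCCC12CCN(c1c(Cl)cncc1-c1ccoc1)CC2` gives 750 nM, compound 2 `O=C1NCCC12CCN(c1c(Cl)cncc1-c1ccsc1)CC2` gives 190 nM and compound 3 `CC(=O)c1ccc(-c2cncc(Cl)c2N2CCC3(CCNC3=O)CC2)s1` gives 1440 nM. Compound 2 thus stands lowest of the three numbers, with a 3.9-fold lower number from compound 1 to compound 2 (0.60 log units; beyond the scatter) and a 7.6-fold higher number from compound 2 to compound 3 (0.88 log units; beyond the scatter) both beyond the scatter, while a 1.9-fold higher number from compound 1 to compound 3 (0.28 log units; within the scatter) stays within it.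

Compound 4 `O=Cc1ccc(-c2cncc(Cl)c2N2CCC3(CCNC3=O)CC2)s1` carries the change (5-formylthiophen-2-yl in place of thiophen-3-yl on an aromatic carbon). Going by the values given here, the one measured step that bears on it directly is a 7.6-fold higher number from compound 2 to compound 3 (0.88 log units; beyond the scatter), which replaces the same thiophen-3-yl by a closely related 5-acetylthiophen-2-yl. A rise of comparable size in this assay is therefore expected for compound 4, estimated at 1200 nM with a range of 400 nM to 3500 nM, that is, a 6.3-fold higher number from compound 2 to compound 4 (0.80 log units; beyond the scatter) is expected.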

Compound 4, concentration for 50% growth inhibition: 750 nM
The estimate for compound 4 lay 1.6-fold (0.20 log units) above the measured number, within the range that was stated.
By their numbers in this assay, from the lowest: compound 2; then compounds 1, 4 and 3 (each within the scatter of the next).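

Compound 3 is no lone case: a 3.9-fold higher number from compound 2 to compound 4 (0.60 log units; beyond the scatter) shows that 5-formylthiophen-2-yl also gives a higher number than thiophen-3-yl on this aromatic carbon. Hydrogen in place of methyl on the carbonyl carbon stays within the scatter at a 1.9-fold lower number from compound 3 to compound 4 (0.28 log units; within the scatter), and 5-formylthiophen-2-yl against furan-3-yl gives no change at the digits printed from compound 1 to compound 4 (within the scatter). Nothing shown explains these steps.

In compounds 3 and 4, the thiophene attachment point and the carbonyl substituent change together, so their contributions cannot be separated. Unsubstituted thiophen-2-yl would separate them, and a carboxylic acid or aminomethyl group in place of the formyl group remains an open question.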